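The source may report more compounds than this note shows. Statements on the series, on what has been measured and on what is new or still open speak of the compounds shown alone.

Working notes on the series.

Three compounds of the shared core have been run through a functional assay on the whole organism (Tail, strain ICR) with Mus musculus as the target, in the tail flick test, with a stated time of 60 min, at a dose of 25 umol/kg by the oral route; a higher number here means a stronger effect of the compound at the dose given, a lower number a weaker effect. Compound 1 `NC(=O)CC[C@H](NC(=O)CN(c1ncnc2c1ncn2C1CCCCO1)C1CC1)C(=O)OCc1ccccc1` gives 39.4%. Compound 2 `O=C(CN(c1ncnc2c1ncn2C1CCCCO1)C1CC1)N[C@@H](CCC(=O)OCc1ccccc1)C(=O)OCc1ccccc1` gives 34.7%. Compound 3 `O=C(CN(c1ncnc2c1ncn2C1CCCCO1)C1CC1)N[C@@H](CO)C(=O)OCc1ccccc1` gives 46.7%. Going by the values given here, the step of a number 4.7 percentage points lower from compound 1 to compound 2 (within the scatter) and the step of a number 7.3 percentage points higher from compound 1 to compound 3 (within the scatter) both stay within the scatter; only the step of a number 12 percentage points higher from compound 2 to compound 3 (beyond the scatter) passes beyond it. Compound 3 therefore sits above compound 2 by a modest margin and level with compound 1 within the scatter; the numbers do not allow it to be called the strongest of the three.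

Compound 4 `NC(=O)C[C@H](NC(=O)CN(c1ncnc2c1ncn2C1CCCCO1)C1CC1)C(=O)OCc1ccccc1` is not yet measured. It differs from compound 3 as follows: carbamoyl in place of hydroxy on a saturated chain carbon, two bonds along the chain from an amide-type nitrogen and a carbonyl carbon. Among the compounds with values here, the one measured step that bears on this change is the step of a number 7.3 percentage points higher from compound 1 to compound 3 (within the scatter), where a carbamoylmethyl group at the same place was exchanged for hydroxy without leaving the scatter. Compound 4 carries the carbamoyl one bond closer to the chain than compound 1 does, so the move from compound 3 is read as the reverse of that step with a shorter arm. No step beyond the scatter is expected in this assay, in either direction.

Compound 4 is estimated at 42%, with a range from 30% to 55%; the expected step of a number 4.7 percentage points lower from compound 3 to compound 4 (within the scatter) lies within the scatter.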

Compound 4, a percentage reported as activity, at one dose (the size of the read-out at that dose, not a potency): 30.5%
Compound 4: the middle estimate sits 11.5 percentage points above what was measured; measured number inside the range.
By their numbers in this assay, from the lowest: compounds 4, 2, 1 and 3 (each within the scatter of the next, the first and the last beyond it).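

In this assay, going by these compounds alone, the exchange of hydroxy for carbamoyl on this saturated chain carbon gives the first step at this place that starts from compound 3 and passes beyond the scatter (a number 16.2 percentage points lower from compound 3 to compound 4 (beyond the scatter)), although still by a modest margin; the longer carbamoylmethyl arm of compound 1 had stayed within the scatter of compound 3. The position therefore does respond to the group it carries, and the response depends on the arm and not on the carbamoyl group alone, since hydroxymethyl and carbamoylmethyl read as level while hydroxy and carbamoyl do not. The other two new steps stay within the scatter (a number 4.2 percentage points lower from compound 2 to compound 4 (within the scatter); a number 8.9 percentage points lower from compound 1 to compound 4 (within the scatter)), so compound 4 is level with compound 2 and compound 1, and compound 3 now lies clear of compound 2 and compound 4 but not of compound 1.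

The compounds shown leave open how a carboxylic acid, an amine or a longer carbamoyl chain on this saturated chain carbon would read in this assay. No measurement at hand speaks to what lies behind the gap between compound 3 and compound 4.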